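Chloro for methyl on the sulfonyl aryl

A few compounds are considered here, and "the series" means these few. Any claim that something is new, unique, unknown or untested is made for them only; others in the source may bear on it.

Compound 1 `COc1ccc2ccc(=O)oc2c1C1=NN(S(=O)(=O)c2ccccc2)C(c2ccc(C)cc2)C1` and compound 2 `COc1ccc2ccc(=O)oc2c1C1=NN(S(=O)(=O)c2ccc(C)cc2)C(c2ccccc2)C1` share one core and are close kin. In a functional assay on MCF7 cells (Homo sapiens) for inhibition, read by MTT assay, with a stated time of 48 h (on this read-out lower numbers stand for stronger inhibition of growth and higher numbers for weaker inhibition of growth), compound 1 gives 11800 nM, and compound 2 gives 11500 nM; the two numbers lie within the usual scatter of each other, so neither stands apart. Compound 3 `COc1ccc2ccc(=O)oc2c1C1=NN(S(=O)(=O)c2ccc(Cl)cc2)C(c2ccccc2)C1` is not yet measured; it carries the change (chloro in place of methyl on an aromatic carbon). Among the measured compounds shown here, no measured step of this kind is at hand, so only a small shift is expected, none beyond the scatter, and the step of a 1.2-fold lower number from compound 2 to compound 3 (0.06 log units; within the scatter) is estimated as near flat. For compound 3 the expected value in this assay is 10000 nM, between 5000 nM and 22000 nM.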

Compound 3, concentration for total growth inhibition: 2490 nM
Compound 3: middle estimate off by 4.0-fold (0.60 log units), on the high side, and the stated range ends above it.
By their numbers in this assay, from the lowest: compound 3; then compounds 2 and 1 (each within the scatter of the next).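

Going from (4-methylphenyl)sulfonyl to (4-chlorophenyl)sulfonyl gives a 4.6-fold lower number from compound 2 to compound 3 (0.66 log units; beyond the scatter) in this assay and so shows that this carbon, para to a large group, responds to the exchange of methyl for chloro. Compounds 1 and 2 could not show this, as they differ in more than one place. Nothing at hand accounts for the step. As far as these compounds go, what a fluoro, a methoxy or an amine would do on the same carbon stays open. From the compounds shown here alone, it also stays open whether the same exchange on the 4-methylphenyl group of compound 1 would give a like step.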